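Chromone cytotoxicity series: from compound 2 to compound 3

The compounds below may be only part of what the source reports. "The series", "measured", "known", "first", "only" and "open" are said of these compounds alone.

Measured so far in a functional assay on HeLa cells (Homo sapiens) for cytotoxicity, read by neutral red uptake, with a stated time of 3 days; a higher number here means a weaker inhibitor, a lower number a stronger inhibitor:
compound 1, `CCCCCCc1c(F)c(N)c2c(=O)cc(-c3ccc(N)c(F)c3)oc2c1F`: 21000 nM
compound 2, `Nc1ccc(-c2cc(=O)c3c(N)c(F)c(Cl)c(F)c3o2)cc1F`: > 100000 nM

Compound 2 gives only a limit in this assay, (the limit of > 100000 nM in this assay, at which 1 of the 2 values shown sits), so its place is at the top end of the numbers shown and is not fixed by an actual value. Within the data shown here, the single measured step is an at least 4.7-fold higher number from compound 1 to compound 2 (0.67 log units; beyond the scatter). Compound 3, `CCC(=O)OCc1c(F)c(N)c2c(=O)cc(-c3ccc(N)c(F)c3)oc2c1F`, differs from compound 2 by (propanoyloxy)methyl in place of chloro on an aromatic carbon. Among the measured compounds shown here, only that one step bears on this change, and it bears only partly: the chloro that enters in compound 2 leaves again, but the (propanoyloxy)methyl that enters is not the hexyl of compound 1, so the outcome is open. The estimated step is an at least 2.0-fold lower number from compound 2 to compound 3 (0.30 log units; that floor lies within the scatter), toward the number of compound 1 but short of it. Compound 3 is therefore expected near 50000 nM, with a range from 15000 nM to 150000 nM.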

Compound 3, half-maximal inhibitory concentration: 69000 nM
For compound 3 the middle estimate is 1.4-fold (0.14 log units) below the measured one, within the range that was stated.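

In this assay, the position on the aromatic carbon flanked by the two fluoro groups now carries two chains with actual values, and swapping the chain end gives a 3.3-fold higher number from compound 1 to compound 3 (0.52 log units; beyond the scatter): propanoyloxy in place of pentyl on the saturated chain carbon bound to the aromatic carbon is a modest change, so this site responds to what the chain carries and not only to whether a chain is present. The comparison with chloro is weaker, with an at least 1.4-fold lower number from compound 2 to compound 3 (0.16 log units; that floor lies within the scatter), a floor that establishes no change beyond the scatter. Compound 2 gives only a limit: the limit of > 100000 nM in this assay, at which 1 of the 3 values shown sits.

On these data alone, how far compound 2 lies from compound 3 therefore stays open. So does how a hydroxymethyl, a carboxylic acid or an aminomethyl group at this position would read in this assay.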